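The source may report more compounds than this note shows. Statements on the series, on what has been measured and on what is new or still open speak of the compounds shown alone.

Measured in a functional assay for inhibition, tested at 20 ug/mL; a lower number here means a weaker effect, a higher number a stronger effect of the compound at the concentration tested:

- compound 1 `COc1cc(-c2cc(-c3cc(C(C)C)c(O)cc3C)[nH]c(=O)c2C#N)cc(OC)c1OC`: compound 1 gives 35%
- compound 2 `Cc1cc(O)c(C(C)C)cc1-c1cc(-c2cccs2)c(C#N)c(=O)[nH]1`: compound 2 gives 26%
- compound 3 `COc1cc(OC)c(-c2cc(-c3cc(C(C)C)c(O)cc3C)[nH]c(=O)c2C#N)c(OC)c1`: compound 3 gives 32%

Compound 2 has the lowest of the three numbers, but its nearest neighbour, compound 3, sits higher only within the scatter, and the furthest, compound 1, also sits higher only within the scatter. On these numbers the three compounds are not separable, and nothing can be said about which of them is the stronger in this assay.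

The step to be followed goes from compound 2 to compound 4 `Cc1cc(O)c(C(C)C)cc1-c1cc(-c2ccc(N(C)C)cc2)c(C#N)c(=O)[nH]1`. The change is 4-(dimethylamino)phenyl in place of thiophen-2-yl on an aromatic carbon. The two aryl analogues already in hand, compound 1 and compound 3, each carry a six-membered ring at the same place and give numbers that do not part from compound 2 beyond the scatter.

Within the data shown here, no pair of compounds differing in one place has been measured here, so the size of the step is not anchored. Given that compound 1 with 35% and compound 3 with 32% both fall close to compound 2, the expected step from compound 2 to compound 4 is a number 4 percentage points higher from compound 2 to compound 4 (within the scatter), that is, none beyond the scatter in either direction.

For compound 4 the estimate in this assay is therefore 30%, with a range from 15% to 45%.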

Compound 4, a percentage reported as inhibition, at one concentration (the size of the read-out at that concentration, not a potency): 30%
For compound 4 middle estimate and measured number coincide at the digits printed; the range from low to high includes it.
By their numbers in this assay, from the lowest: compounds 2, 4, 3 and 1 (each within the scatter of the next).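

In this assay, among these compounds, the only pair differing in one place gives a number 4 percentage points higher from compound 2 to compound 4 (within the scatter) when 4-(dimethylamino)phenyl replaces thiophen-2-yl on the aromatic carbon ortho to a cyano group. Among the compounds shown here, this is the first direct reading at this position: a five-membered aromatic ring with 1 hetero atom and a six-membered aromatic ring of carbon only, carrying 5 and 9 heavy atoms, cannot be told apart in this read-out at the single concentration tested. The exchange therefore shows that this position accepts the larger group with no separation beyond the scatter, though the read-out is not a potency and the finding holds for this one pair alone; no independent measurement accompanies the result that could account for it.

Open, on these data alone, is whether a carboxylic acid, a primary aminoalkyl chain or a morpholine ring on this aromatic carbon would part from thiophen-2-yl beyond the scatter. Also open, as far as these compounds go, is how the read-out responds to changes elsewhere on the shared core, such as replacing the hydroxy group with methoxy or the nitrile with a carboxamide.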